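A few compounds are considered here, and "the series" means these few. Any claim that something is new, unique, unknown or untested is made for them only; others in the source may bear on it.

Measured in a functional assay on VCaP cells (Homo sapiens) for antiproliferative activity, read by propidium iodide staining, with a stated time of 96 h; a higher number here means a weaker inhibitor, a lower number a stronger inhibitor:
- compound 1 `CC(O)(COc1ccccc1C(F)(F)F)C(=O)Nc1ccc(S(F)(F)(F)(F)F)cc1`: 3100 nM
- compound 2 `CC(O)(COc1ccc(C#N)cc1)C(=O)Nc1ccc(S(F)(F)(F)(F)F)cc1`: 100000 nM

Of these two compounds, compound 2 has the higher number, which makes it the weaker inhibitor. Compound 3 `CC(O)(COc1ccc(C#N)cc1C(F)(F)F)C(=O)Nc1ccc(S(F)(F)(F)(F)F)cc1` has not yet been measured. It differs from compound 2 by a single change: trifluoromethyl in place of hydrogen on an aromatic carbon.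

For the measured compounds named here, only one measured step bears on this change. That large step, a 32-fold higher number from compound 1 to compound 2 (1.51 log units; beyond the scatter), put 4-cyanophenyl in place of 2-(trifluoromethyl)phenyl, so it removed the trifluoromethyl and added the cyano group at once. It therefore cannot separate their contributions. Compound 3 carries both groups, so part of that step may be reversed, and a sizeable move towards a lower number is expected in this assay. The expected change is a 13-fold lower number from compound 2 to compound 3 (1.10 log units; beyond the scatter). The estimate for compound 3 is 8000 nM, with an expected range of 1500 nM to 45000 nM.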

Compound 3, half-maximal inhibitory concentration: 100000 nM
Compound 3: the middle estimate sits 13-fold (1.10 log units) below what was measured, and the stated range ends below it.
By their numbers in this assay, from the lowest: compound 1; then compounds 2 and 3 (each within the scatter of the next).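

In this assay trifluoromethyl in place of hydrogen on this aromatic carbon gives no change at the digits printed from compound 2 to compound 3 (within the scatter) when the cyano group is present, so the added group brings no measurable gain in that setting. Cyano in place of hydrogen, with trifluoromethyl kept, gives a 32-fold higher number from compound 1 to compound 3 (1.51 log units; beyond the scatter) and this ties the large drop seen earlier to the arrival of the cyano group, not to the loss of trifluoromethyl. No measurement here explains why the cyano group has this effect.

The compounds shown leave open what trifluoromethyl does on a ring without the cyano group, since no compound here lacks both groups. They also leave open whether a different group in the cyano group's place, such as an amine or a carboxylic acid, would keep or improve the activity of compound 1.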